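Compound 2 Loses a Benzimidazole, Gains a Benzoxazole

The compounds below may be only part of what the source reports. "The series", "measured", "known", "first", "only" and "open" are said of these compounds alone.

In a functional assay on HL-60 cells (Homo sapiens) for antiproliferative activity, read by MTT assay, with a stated time of 48 h (on this read-out higher numbers stand for weaker inhibition and lower numbers for stronger inhibition), compound 1 `Cn1c(N)c(-c2nc3ccccc3[nH]2)c2nc(C#N)c(C#N)nc21` gives only a limit, > 50000 nM.

Within the data shown here, compound 2 `CCN(CC)CCCCn1c(N)c(-c2nc3ccccc3[nH]2)c2nc(C#N)c(C#N)nc21`, which carries a 4-(diethylamino)butyl group on the shared core, gives 460 nM, the only true number so far. Among the measured compounds shown here, the one measured step, an at least 100-fold lower number from compound 1 to compound 2 (2.03 log units; beyond the scatter), concerns that chain and not the aromatic carbon at issue here, so it bears on the new change only indirectly.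

Compound 3 `CCN(CC)CCCCn1c(N)c(-c2nc3ccccc3o2)c2nc(C#N)c(C#N)nc21` keeps the chain and alters a single group: 1,3-benzoxazol-2-yl in place of 1H-benzimidazol-2-yl on an aromatic carbon. For the measured compounds named here, no measured step tests this exchange. With the chain of the step of an at least 100-fold lower number from compound 1 to compound 2 (2.03 log units; beyond the scatter) retained in compound 3, no loss of that size is expected. The expected change is instead a modest one towards a higher number, a 2.0-fold higher number from compound 2 to compound 3 (0.29 log units; within the scatter). The estimate for compound 3 is 900 nM, with an expected range of 250 nM to 3500 nM.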

Compound 3, half-maximal inhibitory concentration: 450 nM
Beside the measured number, compound 3's estimate is 2.0-fold (0.30 log units) above it; low and high end bracket the measured number.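

On the aromatic carbon that bears it, 1,3-benzoxazol-2-yl in place of 1H-benzimidazol-2-yl gives a 1.0-fold lower number from compound 2 to compound 3 (0.01 log units; within the scatter) in this assay, whereas the earlier step concerned only the chain. With the 4-(diethylamino)butyl group kept, this position therefore accepts the exchange of a ring nitrogen carrying a hydrogen-bond donor for a ring oxygen, so that donor is not needed to hold the number in this pair. The data shown offer no explanation for this outcome.

As far as these compounds go, whether a sulfur-containing 1,3-benzothiazol-2-yl or a plain phenyl ring on the same carbon would do as well remains open. So does whether the same exchange would give a similar result with a shorter amine chain in place of the 4-(diethylamino)butyl group.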